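A weak series against a peptidase, tested again

The compounds below may be only part of what the source reports. "The series", "measured", "known", "first", "only" and "open" are said of these compounds alone.

Compound 1 `CC#CCn1c(N2CCC[C@@H](N)C2)nc2c1c(=O)n(Cc1ccccc1C(=O)O)c(=O)n2C` in an ADME assay on isolated protein for inhibition of Dipeptidyl peptidase 9 (Homo sapiens), with stated times of 15 min, 60 s and 20 min (on this read-out higher numbers stand for weaker inhibition and lower numbers for stronger inhibition), gives > 100000 nM, which is a limit of the assay and not a number.
Compound 2 `CC#CCn1c(N2CCC[C@@H](N)C2)nc2c1c(=O)n(Cc1cccc(F)c1C(=O)OC)c(=O)n2C` gives > 100000 nM, again a limit.
Compound 3 `CC#CCn1c(N2CCC[C@@H](N)C2)nc2c1c(=O)n(Cc1ccc(Cl)cc1C(=O)OCC)c(=O)n2C` gives > 100000 nM, again a limit.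

Among the measured compounds shown here, compound 3 thus stands at the limit of this assay, as the limit of > 100000 nM in this assay, at which 3 of the 3 values shown sit, records; every value shown sits there, so no compound is separated from another. The step to compound 4 `CC#CCn1c(N2CCC[C@@H](N)C2)nc2c1c(=O)n(Cc1c(OC)cccc1C(=O)O)c(=O)n2C` exchanges (2-carboxy-6-methoxyphenyl in place of 4-chloro-2-(ethoxycarbonyl)phenyl on a saturated chain carbon bound to an aromatic nitrogen). The measured steps a step that the two limits leave unreadable from compound 1 to compound 3 and a step that the two limits leave unreadable from compound 2 to compound 3 touch the same position yet cannot be read; both of their ends are limits. Nothing among the shown compounds points in any direction, so compound 4 is expected to stay at the limit as well, with a step that the limit leaves unreadable from compound 3 to compound 4 as the expected step. Compound 4 is therefore estimated at 150000 nM, between 50000 nM and 500000 nM, and most likely reported only as a limit.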

Compound 4, half-maximal inhibitory concentration: > 100000 nM
Compound 4 was reported as a limit; the forecaster's own chance of this, stated with the estimate: 85%; the middle value does not contradict the limit.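

The steps from compound 1, compound 2 and compound 3 to compound 4 cannot be read, because both ends of each step are limits: the limit of > 100000 nM in this assay, at which 4 of the 4 values shown sit.
The compounds shown leave open how strongly any of them inhibits the peptidase, and which change, if any, would give a measurable value.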